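This account rests on a few compounds, and the source may have more. Where it says the series, first, only, none or still open, it means among the compounds named here.

Working notes on the series

Compound 1 `OC[C@H]1O[C@@H](n2cnc3c(NCc4ccccc4F)ncnc32)[C@H](O)[C@@H]1O`, compound 2 `OC[C@H]1O[C@@H](n2cnc3c(NCc4cccc(F)c4)ncnc32)[C@H](O)[C@@H]1O` and compound 3 `OC[C@H]1O[C@@H](n2cnc3c(NCc4ccc(Cl)cc4)ncnc32)[C@H](O)[C@@H]1O` share one core and differ only in the substituted phenyl carried on a saturated chain carbon bound to a nitrogen on an aromatic ring. In a functional assay on G-361 cells (Homo sapiens) for antiproliferative activity, with a stated time of 72 h (on this read-out lower numbers stand for stronger inhibition and higher numbers for weaker inhibition), compound 1 is entered as "not determined" (no result reported). Compound 2 gives only a limit of this assay, > 166000 nM. Compound 3 also gives only a limit, > 166000 nM. For the measured compounds named here, the one step with two measured ends, a step that the two limits leave unreadable from compound 2 to compound 3, is thus of no readable size, and compound 3 stands on no number, only on (the limit of > 166000 nM in this assay, at which 2 of the 3 values shown sit).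

Compound 4 `OC[C@H]1O[C@@H](n2cnc3c(NCc4cccc(Br)c4)ncnc32)[C@H](O)[C@@H]1O` is the next member; the change is 3-bromophenyl in place of 4-chlorophenyl on a saturated chain carbon bound to a nitrogen on an aromatic ring. Going by the values given here, no measured step speaks to this change: the single step between measured compounds leaves its size unreadable, and nothing else in the set touches a bromine on this ring. Compound 4 is therefore expected to return another limit rather than a number, with an estimated value of 200000 nM and a range of 50000 nM to 1000000 nM. The expected step that the limit leaves unreadable from compound 3 to compound 4 is accordingly nothing beyond the scatter.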

Compound 4, half-maximal inhibitory concentration: > 166000 nM
Compound 4: a limit, no number (the forecaster's own chance of this, stated with the estimate: 85%); the middle value does not contradict the limit.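

Compound 4 gives only a limit, so its steps from compound 2 and from compound 3 cannot be read: the limit of > 166000 nM in this assay, at which 3 of the 4 values shown sit.

The compounds shown leave open how the fluoro, chloro and bromo substituents on the phenyl would rank on a readable number in this assay.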